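Compound 1 to compound 4: phenyl on the carbonyl

The source may report more compounds than this note shows. Statements on the series, on what has been measured and on what is new or still open speak of the compounds shown alone.

In a functional assay on Malme-3M cells (Homo sapiens) for inhibition, read by sulforhodamine B assay, with a stated time of 48 h (a higher number here means a weaker inhibitor of growth, a lower number a stronger inhibitor of growth), compound 1 (`COc1cc(-c2nn(-c3cccc(NC(=O)Nc4ccc(Cl)c(Cl)c4)c3)cc2-c2ccncc2)ccc1Cl`) gives 926 nM, compound 2 (`O=C(Nc1cccc(-n2cc(-c3ccncc3)c(-c3ccc(Cl)c(O)c3)n2)c1)Nc1ccc(Cl)c(Cl)c1`) gives 1190 nM and compound 3 (`O=C(Nc1cccc(-n2cc(-c3ccncc3)c(-c3ccc(Cl)c(O)c3)n2)c1)Nc1cc(C(F)(F)F)cc(C(F)(F)F)c1`) gives 939 nM. These three values lie within the scatter of one another, so compound 1 stands level with the other two.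

The next compound is compound 4 (`COc1cc(-c2nn(-c3cccc(NC(=O)c4ccccc4)c3)cc2-c2ccncc2)ccc1Cl`), and its change from compound 1 is phenyl in place of (3,4-dichlorophenyl)amino on a carbonyl carbon. For the measured compounds named here, the only measured step, a 1.3-fold higher number from compound 1 to compound 2 (0.11 log units; within the scatter), lies elsewhere on the molecule and stays within the scatter. It says little about this change. Compound 3, which carries no (3,4-dichlorophenyl)amino group, gives 939 nM, but it still keeps a nitrogen on the carbonyl. Going by the values given here, no measured compound lacks that nitrogen, so the data do not fix the size of the step. A move to a higher number in this assay, meaning weaker growth inhibition, is expected on judgement alone, and the range is kept wide.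

The estimated change is a 3.0-fold higher number from compound 1 to compound 4 (0.48 log units; beyond the scatter). For compound 4 the expected value is 2800 nM, with an estimated range of 900 nM to 9000 nM.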

Compound 4, concentration for 50% growth inhibition: 537 nM
Compound 4: middle estimate off by 5.2-fold (0.72 log units), on the high side; measured number below the stated range.
By their numbers in this assay, from the lowest: compounds 4, 1, 3 and 2 (each within the scatter of the next, the first and the last beyond it).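

The step of a 1.7-fold lower number from compound 1 to compound 4 (0.24 log units; within the scatter) in this assay comes with phenyl in place of (3,4-dichlorophenyl)amino on a carbonyl carbon, and it stays within the scatter. For this pair, the carbonyl carbon therefore takes a group without the amino nitrogen or either chlorine, and with fewer heavy atoms, with no change in growth inhibition beyond the scatter. No measurement on hand accounts for this result.

The compounds shown do not tell whether this carbonyl carbon would hold the same level with a methyl group, a longer alkyl chain, or a phenyl ring carrying an amine or a carboxylic acid. They also leave open whether benzamido would read the same in a compound with hydrogen in place of methyl on the aromatic oxygen.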